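Difluorophenyl in place of phenyl on the aromatic nitrogen

The compounds below may be only part of what the source reports. "The series", "measured", "known", "first", "only" and "open" are said of these compounds alone.

Measured in a functional assay on MKN-45 cells (Homo sapiens) for cytotoxicity, read by MTT assay, with a stated time of 72 h; a higher number here means a weaker inhibitor, a lower number a stronger inhibitor:
compound 1 `COc1cc2c(Oc3ccc(NC(=O)c4cn(-c5ccccc5)nn4)cc3F)ccnc2cc1OCCCN1CCCC1` gives 260 nM
compound 2 `COc1cc2c(Oc3ccc(NC(=O)c4cn(-c5ccccc5)nn4)cc3F)ccnc2cc1OCCCN1CCN(C)CC1` gives 60 nM

Among the compounds with values here, compound 2 holds the lowest of the two numbers; the single measured step, a 4.3-fold lower number from compound 1 to compound 2 (0.64 log units; beyond the scatter), concerns the amine on a saturated chain carbon, three bonds along the chain from an oxygen on an aromatic ring. Compound 3 `COc1cc2c(Oc3ccc(NC(=O)c4cn(-c5ccc(F)c(F)c5)nn4)cc3F)ccnc2cc1OCCCN1CCN(C)CC1` differs from compound 2 at another place: 3,4-difluorophenyl in place of phenyl on an aromatic nitrogen. Within the data shown here, the chain amine is identical in compound 2 and compound 3, so the one measured step says nothing about the aryl group on the ring nitrogen, and no other pair in the set varies there. With no comparator for this change, the expected step in this assay from compound 2 to compound 3 is no change at the digits printed from compound 2 to compound 3 (within the scatter), none beyond the scatter, with the range widened for the missing precedent. Compound 3 is expected at 60 nM, between 20 nM and 180 nM.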

Compound 3, half-maximal inhibitory concentration: 160 nM
Beside the measured number, compound 3's estimate is 2.7-fold (0.43 log units) below it; low and high end bracket the measured number.
By their numbers in this assay, from the lowest: compound 2; then compounds 3 and 1 (each within the scatter of the next).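

In this assay, 3,4-difluorophenyl in place of phenyl on the aromatic nitrogen gives a 2.7-fold higher number from compound 2 to compound 3 (0.43 log units; beyond the scatter) with the 4-methylpiperazin-1-yl chain amine held fixed. Within the data shown here, this is the first reading at this position: the aryl group on the ring nitrogen affects the number, and the two added fluorines do not improve on phenyl in this pair. No measurement at hand gives a reason for the step.

A 3-fluorophenyl or 4-fluorophenyl group on the same nitrogen would show whether one fluorine alone accounts for the step, and a pyridyl or benzyl group would show how the position responds to a different ring or a longer link. Going by these compounds, it also remains open whether the step from phenyl to 3,4-difluorophenyl carries over when the chain ends in pyrrolidin-1-yl.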